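The compounds below may be only part of what the source reports. "The series", "measured", "known", "first", "only" and "open" are said of these compounds alone.

Compound 1 `O=C(/C(=C\c1ccc(OCc2ccccc2)cc1)SCc1ccc(Cl)cc1)c1ccc(Cl)cc1` is the starting point. In a functional assay on DU-145 cells (Homo sapiens) for inhibition, read by trypan blue exclusion, with a stated time of 96 h (a lower number here means a stronger inhibitor of growth, a higher number a weaker inhibitor of growth), compound 1 gives 1000 nM. Two relatives have been measured the same way: compound 2 `Cc1cc(C)cc(/C=C(\C(=O)c2ccc(Cl)cc2)S(=O)(=O)Cc2ccc(Cl)cc2)c1` gives 1000 nM, and compound 3 `O=C(/C(=C\c1ccc(OCc2ccccc2)cc1)S(=O)(=O)Cc1ccc(Cl)cc1)c1ccc(Cl)cc1` gives 1000 nM. Within the data shown here, compound 1 therefore stands level with compounds 2 and 3, and the only single-point step measured so far, no change at the digits printed from compound 1 to compound 3 (within the scatter), was flat. Compound 4 `CN(C)c1ccc(/C=C(/SCc2ccc(Cl)cc2)C(=O)c2ccc(Cl)cc2)cc1` is the next compound; it differs from compound 1 in one place: dimethylamino in place of benzyloxy on an aromatic carbon. Among the measured compounds shown here, no measured step touches this part of the shared core, so nothing among the measured compounds speaks for a move in either direction; all that is known is that the three measured compounds give the same value and that the one step measured elsewhere on the core produced no change beyond the scatter. The expected step is thus small, no change at the digits printed from compound 1 to compound 4 (within the scatter), with no preferred direction. For compound 4 the expected value in this assay is 1000 nM, estimated to lie between 400 nM and 2500 nM.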

Compound 4, concentration for 50% growth inhibition: > 100000 nM
Compound 4 gave a limit, no number; the forecaster's own chance of this, stated with the estimate: 20%; middle value at least 100-fold (2.00 log units) from the limit.
By their numbers in this assay, from the lowest: compounds 1, 2 and 3 (each within the scatter of the next). At a limit, above all of these: compound 4.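

Replacing benzyloxy with dimethylamino produces an at least 100-fold higher number from compound 1 to compound 4 (2.00 log units; beyond the scatter) in this assay. The earlier compounds shown here showed only a flat step on the sulfur-bearing side of the shared core, whereas this aromatic carbon, para to a large group, is a place where one change separates a growth inhibitor from a much weaker one. The result for compound 4 is a limit of the assay and not a number, so the true size of the step stays unknown: the limit of > 100000 nM in this assay, at which 1 of the 4 values shown sits.

The change removes a ring and brings in a nitrogen at once, and the compounds shown cannot separate these two parts of the swap. A methoxy group on this carbon would keep the oxygen without the ring, while a benzylamino group would keep the ring and carry a nitrogen, so each would test one part alone.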